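The source may hold more compounds than are shown below. What is called first, only, known or untested is meant among the compounds shown, and "the series" means these compounds.

Four esters of a macrocyclic polyether alcohol are compared in a functional assay on HeLa cells (Homo sapiens) for inhibition, read by sulforhodamine B assay, with a stated time of 48 h; on this read-out higher numbers stand for weaker inhibition of growth and lower numbers for stronger inhibition of growth. Compound 1 `O=C(/C=C/c1ccccc1)OCC1COCCOCCOCCOCCOCCO1` carries a cinnamate-type group and gives 48000 nM. Compound 2 `CC/C=C/CC(=O)OCC1COCCOCCOCCOCCOCCO1` has a pent-2-en-1-yl group on the carbonyl carbon instead; in this assay compound 2 reaches only the limit of > 100000 nM. The step of an at least 2.0-fold higher number from compound 1 to compound 2 (0.31 log units; beyond the scatter) therefore goes toward weaker growth inhibition. Compound 3 `O=C(CCCCC1CCCCC1)OCC1COCCOCCOCCO1`, with a smaller polyether ring and a cyclohexyl-terminated chain, also sits at the limit, giving > 100000 nM. So compound 2 stands at the weak end of what this assay could resolve, at the same limit as compound 3, as noted in the limit of > 100000 nM in this assay, at which 2 of the 3 values shown sit.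

Compound 4 `O=C(CCCCc1ccccc1)OCC1COCCOCCOCCOCCOCCO1` differs from compound 2 by 3-phenylpropyl in place of but-1-en-1-yl on a saturated chain carbon bound to a carbonyl carbon. This brings back an aromatic ring, as in compound 1, but on a saturated chain rather than a double bond. Going by the values given here, only the step from compound 1 to compound 2 bears on this, and it was at least modest in the other direction. A return toward the value of compound 1 is expected, though a value at the limit remains possible. Compound 4 is expected to give about 80000 nM, between 30000 nM and 200000 nM, so the estimated step of an at least 1.2-fold lower number from compound 2 to compound 4 (0.09 log units; that floor lies within the scatter) points toward stronger inhibition.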

Compound 4, concentration for 50% growth inhibition: 52000 nM
Beside the measured number, compound 4's estimate is 1.5-fold (0.19 log units) above it; the measured number falls inside the stated range.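

Putting 4-phenylbutyl in place of 2-phenylethenyl on the carbonyl carbon gives a 1.1-fold higher number from compound 1 to compound 4 (0.03 log units; within the scatter), so an aromatic ring on a saturated chain does as well here as one on a double bond. Putting 3-phenylpropyl in place of but-1-en-1-yl gives an at least 1.9-fold lower number from compound 2 to compound 4 (0.28 log units; that floor lies within the scatter), which hints that the aromatic ring restores growth inhibition, although that floor alone does not establish it. Compound 2 gives only a limit, so the true size of this step stays unknown: the limit of > 100000 nM in this assay, at which 2 of the 4 values shown sit.

The compounds shown leave open whether the aromatic ring itself counts or simply the greater chain size, which a straight octyl chain on the same core could help to separate. Also open, from the compounds shown here alone, is how a carboxylic acid or an amine on the aromatic ring of 4-phenylbutyl would fare.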